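The source may report more compounds than this note shows. Statements on the series, on what has been measured and on what is new or still open speak of the compounds shown alone.

Among the compounds with values here, compound 1, with the structure `COC(=O)C1=C(C)N=C(C)/C(=C(\O)OC)C1c1ccc(Cl)cc1`, is one of two compounds measured in a functional assay (muscle tissue) with Cavia porcellus as the target (on this read-out higher numbers stand for an effect only at larger amounts of compound and lower numbers for an effect already at smaller amounts), and in this assay compound 1 gives 8130 nM, the highest of the two numbers. The other measured compound, compound 2, has the structure `COC(=O)C1=C(C)N=C(C)/C(=C(\O)OC)C1c1cccc(C(F)(F)F)c1` and gives 74.1 nM in this assay, a number far lower than that of compound 1 and well beyond the usual scatter of repeated measurements. The two compounds differ in the aryl group that sits on the saturated ring carbon of the shared core, while everything else in the core is the same.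

Compound 3, with the structure `COC(=O)C1=C(C)N=C(C)/C(=C(\O)OC)C1c1cccc(C#N)c1`, has not yet been measured in this assay. Compared with compound 1, compound 3 carries the change (3-cyanophenyl in place of 4-chlorophenyl on a saturated ring carbon). On the basis of compound 1 and the value of compound 2, the 3-cyanophenyl compound is expected to move toward lower numbers, with the expected step of a 27-fold lower number from compound 1 to compound 3 (1.43 log units; beyond the scatter) reaching beyond the scatter. For compound 3 in this assay the estimate is 300 nM, with a range from 60 nM to 1500 nM.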

Compound 3, half-maximal effective concentration: 34.7 nM
The estimate for compound 3 lay 8.6-fold (0.94 log units) above the measured number, outside the stated range (below it).
By their numbers in this assay, from the lowest: compound 3; then compound 2; then compound 1.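

In this assay, replacing the 4-chlorophenyl group of compound 1 with 3-cyanophenyl gives a 230-fold lower number from compound 1 to compound 3 (2.37 log units; beyond the scatter), so a second aryl group on the saturated ring carbon reaches a number far below that of compound 1. Within the data shown here, the change of cyano in place of trifluoromethyl on an aromatic carbon gives a 2.1-fold lower number from compound 2 to compound 3 (0.33 log units; beyond the scatter), a modest step but one beyond the scatter, and this pair shows for the first time what exchanging only the group on the aryl ring does while its place stays the same. Among these compounds, compound 3 thereby has the lowest number of the three, and two different groups at that place on the aryl ring both stand well below compound 1, although a pattern resting on only two such compounds remains narrow.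

Compound 1 differs from the other two both in its group and in where that group sits on the aryl ring, so the compounds shown cannot separate these two changes, and they leave open how a plain phenyl, or a nitro or methoxy group on the aryl ring, would read out. No measurement is available here that would explain any of these differences.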